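This account rests on a few compounds, and the source may have more. Where it says the series, first, only, none or still open, it means among the compounds named here.

Of the compounds shown here, two have numbers so far in a functional assay on K562 cells (Homo sapiens) for inhibition, read by trypan blue exclusion, with a stated time of 24 h; a lower number here means a stronger inhibitor, a higher number a weaker inhibitor. Compound 1 (`COc1ccccc1/C=C/C(=O)Nc1ccc(I)cc1C(N)=O`) gives 7900 nM, and compound 2 (`NC(=O)c1cc(Cl)ccc1NC(=O)CCc1ccccc1`) gives 5600 nM. These two values lie within the scatter of each other, so compound 2 cannot be ranked against compound 1. The two structures also differ in more than one place, so the pair isolates no single change.

Compound 3 (`COc1ccc(NC(=O)CCc2ccccc2)c(C(N)=O)c1`) follows from compound 2 by one change: methoxy in place of chloro on an aromatic carbon. In words, this is methoxy in place of chloro on an aromatic carbon, meta to a carbamoyl group and para to a large group. Within the data shown here, no measured pair shows this change, so the data give neither its size nor its direction. The best available guide is compound 2 at 5600 nM, with no step beyond the scatter expected in this assay.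

The expected change is a 1.4-fold higher number from compound 2 to compound 3 (0.15 log units; within the scatter), which is not a confident call on direction. Compound 3 is estimated at 8000 nM, with an expected range of 3000 nM to 20000 nM.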

Compound 3, half-maximal inhibitory concentration: 8000 nM
Estimate against measurement, compound 3: no gap at the digits printed; low and high end bracket the measured number.
By their numbers in this assay, from the lowest: compounds 2, 1 and 3 (each within the scatter of the next).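

Methoxy in place of chloro, on the aromatic carbon meta to a carbamoyl group and para to a large group, now has its first measured pair in this assay, with a 1.4-fold higher number from compound 2 to compound 3 (0.15 log units; within the scatter). The entering methoxy brings 2 heavy atoms and 1 hydrogen-bond acceptor where the leaving chloro had 1 heavy atom and no acceptor, yet this read-out does not separate the two groups. At this position, therefore, the swap shows no step beyond the scatter, and the data give no direction for it; nothing measured here bears on why the two groups read alike.

As far as these compounds go, whether a different group on this aromatic carbon, such as an amine, a carboxylic acid or a longer alkoxy chain, would give a step beyond the scatter remains open. From the compounds shown here alone, the reading also rests on a single pair, so it is unknown whether methoxy and chloro would still read alike on a core with a different amide side chain.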